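Replacing 2,6-dichlorophenyl with 2-fluorophenyl in compound 3

The source may report more compounds than this note shows. Statements on the series, on what has been measured and on what is new or still open speak of the compounds shown alone.

Compound 1 `Nc1ccccc1NC(=O)c1ccc(CNC(=O)c2n[nH]cc2NC(=O)c2c(F)cccc2Cl)cc1`: 16300 nM
Compound 2 `Nc1ccccc1NC(=O)c1ccc(CNC(=O)c2n[nH]cc2NC(=O)c2ccccc2Cl)cc1`: 12900 nM
Compound 3 `Nc1ccccc1NC(=O)c1ccc(CNC(=O)c2n[nH]cc2NC(=O)c2c(Cl)cccc2Cl)cc1`: 7760 nM

In a functional assay on SMMC-7721 cells (Homo sapiens) for inhibition, read by CCK-8 assay, with a stated time of 72 h (on this read-out higher numbers stand for weaker inhibition and lower numbers for stronger inhibition), compound 3 gives 7760 nM. It stands apart beyond the scatter from only one of the other two: the data show a 2.1-fold lower number from compound 1 to compound 3 (0.32 log units; beyond the scatter), but also a 1.7-fold lower number from compound 2 to compound 3 (0.22 log units; within the scatter). Compound 4 `Nc1ccccc1NC(=O)c1ccc(CNC(=O)c2n[nH]cc2NC(=O)c2ccccc2F)cc1` has not yet been measured. The change is 2-fluorophenyl in place of 2,6-dichlorophenyl on a carbonyl carbon. This replaces one chloro by fluoro and the other by hydrogen, so it runs against both steps above, and each of those steps is small. The remaining comparison, a 1.3-fold lower number from compound 1 to compound 2 (0.10 log units; within the scatter), shows fluoro and hydrogen within the scatter of each other. A modest rise in the number is therefore expected, and the two reversed steps may partly add. The expected step is a 2.3-fold higher number from compound 3 to compound 4 (0.37 log units; beyond the scatter). Compound 4 is estimated at 18000 nM, with an expected range from 9000 nM to 36000 nM.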

Compound 4, half-maximal inhibitory concentration: 6850 nM
For compound 4 the middle estimate is 2.6-fold (0.42 log units) above the measured one; measured number outside the range, below it.
By their numbers in this assay, from the lowest: compounds 4, 3, 2 and 1 (each within the scatter of the next, the first and the last beyond it).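

In this assay, the exchange on the carbonyl carbon gives a 1.1-fold lower number from compound 3 to compound 4 (0.05 log units; within the scatter), and the new single-substituent comparisons read a 1.9-fold lower number from compound 2 to compound 4 (0.27 log units; within the scatter) and a 2.4-fold lower number from compound 1 to compound 4 (0.38 log units; beyond the scatter). The result of putting chloro in place of fluoro on this ring depends on what else the ring carries: the same change on two cores in this assay, a 2.1-fold lower number (0.32 log units; beyond the scatter) from compound 1 to compound 3 and a 1.9-fold higher number (0.27 log units; within the scatter) from compound 4 to compound 2, 4.0-fold (0.60 log units) apart, beyond the scatter of two such steps The same holds for chloro in place of hydrogen: the same change on two cores in this assay, a 1.7-fold lower number (0.22 log units; within the scatter) from compound 2 to compound 3 and a 2.4-fold higher number (0.38 log units; beyond the scatter) from compound 4 to compound 1, 4.0-fold (0.60 log units) apart, beyond the scatter of two such steps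

The four compounds shown carry only chloro, fluoro or hydrogen on this ring, so they leave open how an unsubstituted phenyl, a methyl, a methoxy or an amine would read here. On these data alone, whether this dependence on the second substituent extends beyond these four compounds also remains open.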